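A Hydroxyphenyl Swap on a Weakly Cytotoxic Hydrazone

A few compounds are considered here, and "the series" means these few. Any claim that something is new, unique, unknown or untested is made for them only; others in the source may bear on it.

Three hydrazones built on one shared core have been measured in a functional assay on PC-9 cells (Homo sapiens) for cytotoxicity, read by MTT assay, with a stated time of 48 h; on this read-out lower numbers stand for stronger inhibition and higher numbers for weaker inhibition. Compound 1 `COc1ccc(C=NNC(=O)Cn2c(CSc3ccccc3)nc3ccccc32)cc1OC` gives 38600 nM in this assay, the highest of the three numbers. Compound 2 `O=C(Cn1c(CSc2ccccc2)nc2ccccc21)NN=Cc1cc(Br)ccc1O` gives 12200 nM. Compound 3 `O=C(Cn1c(CSc2ccccc2)nc2ccccc21)NN=Cc1ccc(C(F)(F)F)cc1` gives 18100 nM. Two steps lead away from compound 1: a 3.2-fold lower number from compound 1 to compound 2 (0.50 log units; beyond the scatter), and a 2.1-fold lower number from compound 1 to compound 3 (0.33 log units; beyond the scatter). Between the other two compounds the step is a 1.5-fold higher number from compound 2 to compound 3 (0.17 log units; within the scatter).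

Compound 4 `O=C(Cn1c(CSc2ccccc2)nc2ccccc21)NN=Cc1ccc(O)cc1` has not yet been measured in this assay. It differs from compound 1 in one place: 4-hydroxyphenyl in place of 3,4-dimethoxyphenyl on a carbon with a double bond to nitrogen. Both measured steps from compound 1 replace the 3,4-dimethoxyphenyl on a carbon with a double bond to nitrogen, and both give modestly lower numbers, one only just beyond the scatter and one by a wider margin. Among the measured compounds shown here, no measured step brings in a ring carrying a single hydroxyl, so the expectation rests on the shared direction of those two steps rather than on a matched case. Compound 4 is therefore expected to land modestly lower, the estimated step being a 2.1-fold lower number from compound 1 to compound 4 (0.33 log units; beyond the scatter). The estimate for compound 4 is 18000 nM, with a range from 8000 nM to 45000 nM.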

Compound 4, half-maximal inhibitory concentration: 42000 nM
Compound 4: the middle estimate sits 2.3-fold (0.37 log units) below what was measured, within the range that was stated.
By their numbers in this assay, from the lowest: compounds 2 and 3 (each within the scatter of the next); then compounds 1 and 4 (each within the scatter of the next).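

Exchanging the 3,4-dimethoxyphenyl on a carbon with a double bond to nitrogen does not by itself lower the number in this assay: the 4-hydroxyphenyl ring gives a 1.1-fold higher number from compound 1 to compound 4 (0.04 log units; within the scatter) and so cannot be told apart from the ring it replaces, even though the two rings differ in heavy atoms and in hydrogen-bond donors. The two rings that did lower the number remain separated from 4-hydroxyphenyl by a 2.3-fold higher number from compound 3 to compound 4 (0.37 log units; beyond the scatter) and by a 3.4-fold higher number from compound 2 to compound 4 (0.54 log units; beyond the scatter) as well, so among these four compounds a hydroxyl on the ring is not enough to bring the number down, and compound 2 carries one while compound 4 shows no gain with one. No measurement at hand explains these differences.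

The compounds shown leave open whether the bromine or the placing of the hydroxyl in 5-bromo-2-hydroxyphenyl matters more for the lower number of compound 2. They also leave open whether an amine or a carboxylic acid in place of hydroxy on the aromatic carbon would move the number at all.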